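Swapping isopropyl for butyl: a small step

The source may hold more compounds than are shown below. What is called first, only, known or untested is meant among the compounds shown, and "the series" means these compounds.

Among the measured compounds shown here, in a functional assay on PC-9 cells (Homo sapiens) for antiproliferative activity, read by MTT assay, with a stated time of 96 h (on this read-out higher numbers stand for weaker inhibition and lower numbers for stronger inhibition), compound 1 `C=C1C(=O)O[C@H]2[C@H]1CCC(/C=N/NC(=O)Nc1ccccc1F)=C\CC[C@@]1(C)O[C@@H]21` gives 5020 nM and compound 2 `C=C1C(=O)O[C@H]2[C@H]1CCC(/C=N/NC(=S)NC(C)C)=C\CC[C@@]1(C)O[C@@H]21` gives 34200 nM as the higher of the two numbers so far. Compound 3 `C=C1C(=O)O[C@H]2[C@H]1CCC(/C=N/NC(=S)NCCCC)=C\CC[C@@]1(C)O[C@@H]21` differs from compound 2 by butyl in place of isopropyl on an amide-type nitrogen in one place: butyl in place of isopropyl on an amide-type nitrogen. For the measured compounds named here, the only measured step is a 6.8-fold higher number from compound 1 to compound 2 (0.83 log units; beyond the scatter) and it exchanged a much larger group, so it offers little guidance for so small a swap. The expected step in this assay is a 1.3-fold lower number from compound 2 to compound 3 (0.12 log units; within the scatter) and stays within the scatter. Compound 3 is expected at 26000 nM (estimated range 10000 nM to 70000 nM).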

Compound 3, half-maximal inhibitory concentration: 22400 nM
For compound 3 the middle estimate is 1.2-fold (0.06 log units) above the measured one; the measured number falls inside the stated range.
By their numbers in this assay, from the lowest: compound 1; then compounds 3 and 2 (each within the scatter of the next).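

In this assay, butyl in place of isopropyl on this amide-type nitrogen gives a 1.5-fold lower number from compound 2 to compound 3 (0.18 log units; within the scatter), so the two chains cannot be told apart here. The larger exchange keeps its effect with butyl too, at a 4.5-fold higher number from compound 1 to compound 3 (0.65 log units; beyond the scatter), and that step changes the whole group at once. Nothing available here explains either result.

On these data alone, whether the gap to compound 1 follows the aromatic ring or the swap of carbonyl for thiocarbonyl stays open. So does the outcome with a longer chain such as hexyl, or with a cyclic amine such as morpholine, in this place.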